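Methyl in place of isopropyl: clearance outlook

The source may hold more compounds than are shown below. What is called first, only, known or untested is meant among the compounds shown, and "the series" means these compounds.

For the measured compounds named here, in an ADME assay on microsomes from liver (Homo sapiens) for metabolic stability (a higher number here means faster removal of the compound, a lower number slower removal), compound 1 `CC(C)c1c(NC(=O)Nc2ccnc(C(F)(F)F)c2)cnc2cc(Cl)nn12` gives 61 mL.min-1.g-1, the only exact number so far. Compound 2 `O=C(Nc1cnc(-n2nccn2)c(Cl)c1)Nc1cnc2cc(Cl)nn2c1C1CC1` is reported only as a limit, < 25 mL.min-1.g-1. Compound 3 `Cc1c(NC(=O)Nc2ccnc(C(F)(F)F)c2)cnc2cc(Cl)nn12` keeps the core of compound 1 and carries methyl in place of isopropyl on an aromatic carbon. Going by the values given here, no measured pair isolates this change, so the forecast rests on the structural change alone and remains uncertain. A modest fall in this assay is expected, of a size close to the usual scatter, and a result with no real change would not be surprising. The expected step is a 1.6-fold lower number from compound 1 to compound 3 (0.21 log units; within the scatter). For compound 3 the estimated value is 38 mL.min-1.g-1, with an expected range of 22 mL.min-1.g-1 to 62 mL.min-1.g-1.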

Compound 3, intrinsic clearance in microsomes: < 25 mL.min-1.g-1
Compound 3 was reported as a limit; the forecaster's own chance of this, stated with the estimate: 20%; middle value at least 1.5-fold (0.18 log units) away from the limit.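

In this assay, for the compounds shown here, replacing isopropyl with methyl on this aromatic carbon gives an at least 2.4-fold lower number from compound 1 to compound 3 (0.38 log units; beyond the scatter), the only step that isolates a single place. With the rest of compound 1 unchanged, the group at this position alone is enough to shift the read-out by more than the scatter. The value of compound 3 is a limit, so the step gives only a minimum size and not a full one: the limit of < 25 mL.min-1.g-1 in this assay, at which 2 of the 3 values shown sit.

As far as these compounds go, whether ethyl or an amine at this position would give a number closer to compound 1 or to compound 3 remains open. Compound 2 differs from compound 1 in more than one place, so it cannot show which of its changes matter in this assay.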